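The source may report more compounds than this note shows. Statements on the series, on what has been measured and on what is new or still open speak of the compounds shown alone.

Measured compounds:
Compound 1, `Cc1ccc(C2CNN=C2S(=O)(=O)CC2=NCCS2)cc1`: 52.2%
Compound 2, `O=S(=O)(CC1=NCCS1)C1=NNCC1c1ccc(Cl)cc1`: "not active" (no number reported)

Of the compounds shown here, two have been tested in a functional assay, read by Griess assay, with a stated time of 150 min, tested at 100 ug/mL; a lower number here means a weaker effect, a higher number a stronger effect of the compound at the concentration tested. Compound 1 gives 52.2% in this assay. Compound 2 is reported in this assay only as "not active" (no number reported), with no number behind it, so compound 2 stands at the weak end of what has been seen, but its exact position is not known. Compound 3, `O=S(=O)(CC1=NCCS1)C1=NNCC1c1ccccc1`, has not been measured in this assay yet. The change from compound 2 to compound 3 is hydrogen in place of chloro on an aromatic carbon. Among the compounds with values here, no measured pair shows what this kind of change does in this assay, so the size of the step cannot be taken from other compounds. Compound 3 keeps the whole rest of the structure of compound 2. For compound 3 an activity of about 25% is expected in this assay, estimated within a range from 0% to 55%.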

Compound 3, a percentage reported as activity, at one concentration (the size of the read-out at that concentration, not a potency): "not active" (no number reported)
Compound 3 has no reported number here, so the estimate cannot be set against anything.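

Compound 2 and compound 3 are both reported in this assay only as "not active", with no number behind either, so no step can be read between them. No measurement at hand offers an explanation for this result. Going by these compounds, whether going from 4-chlorophenyl to phenyl changes the activity at all remains open.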